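Removing One Trifluoromethyl From an Inactive Amide

The compounds below may be only part of what the source reports. "The series", "measured", "known", "first", "only" and "open" are said of these compounds alone.

Compound 1 `O=C(Nc1cc(C(F)(F)F)cc(C(F)(F)F)c1)c1cnc(C(F)(F)F)nc1C(F)(F)F` is an amide whose core carries trifluoromethyl groups. In an assay on Jurkat cells for activation of nuclear factor NF-kappa-B complex (Homo sapiens) (a lower number here means a stronger inhibitor, a higher number a weaker inhibitor), compound 1 gives > 10000 nM, which is a limit of the assay rather than a number. Compound 2 `Cc1ncc(C(=O)Nc2cc(C(F)(F)F)cc(C(F)(F)F)c2)c(C(F)(F)F)n1` has been measured twice. In this assay compound 2 gives > 10000 nM; > 10000 nM (2 entries), again a limit. Among the compounds with values here, compound 1 thus stands at the limit of > 10000 nM in this assay, at which 1 of the 2 values shown sits, and with both measured compounds at that boundary no step between measured compounds can be read off.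

Compound 3 `O=C(Nc1cc(C(F)(F)F)cc(C(F)(F)F)c1)c1cnc(C(F)(F)F)nc1` differs from compound 1 in one place: hydrogen in place of trifluoromethyl on an aromatic carbon. Nothing measured here shows how such a change moves potency, so the expectation rests on the position of compound 1 alone. The step expected from compound 1 to compound 3 is a step that the limit leaves unreadable from compound 1 to compound 3, none beyond the scatter in this assay. Compound 3 is expected to give about 15000 nM in this assay, within 3000 nM to 60000 nM, and most likely again only a limit.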

Compound 3, half-maximal inhibitory concentration: > 10000 nM
Compound 3 was reported as a limit; the forecaster's own chance of this, stated with the estimate: 80%; the middle value lies beyond the limit too.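

In this assay compound 3 gives > 10000 nM, a limit of the assay, so no step can be read between compound 1 and compound 3: the limit of > 10000 nM in this assay, at which 2 of the 3 values shown sit.

The compounds shown leave open how far hydrogen in place of trifluoromethyl moves potency, and what would give a measurable value in this assay.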